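The source may report more compounds than this note shows. Statements on the series, on what has been measured and on what is new or still open speak of the compounds shown alone.

Compound 1 `CC(C)c1ccc2c(Nc3cc(C(=O)N[C@@H](C)c4ccccc4)ccc3Sc3ccc(N)cc3)ncnc2n1`: 2.7 h
Compound 2 `CC(C)c1ccc2c(Nc3cc(C(=O)N[C@@H](C)c4ccc(Br)cc4)ccc3Sc3ccc(N)cc3)ncnc2n1`: 2 h

Among the measured compounds shown here, in an ADME assay on the whole organism (strain Sprague-Dawley) for metabolic stability, with Rattus norvegicus as the target, at a dose of 5 mg/kg by the oral route (a lower number here means that the compound disappears faster, a higher number that the compound lasts longer), compound 1 gives 2.7 h, and its only measured neighbour, compound 2, gives 2 h. The two lie within the scatter of each other, so compound 1 cannot be ranked apart from compound 2. Compound 3 `CC(C)c1ccc2c(Nc3cc(C(=O)N[C@@H](C)C4CCCCC4)ccc3Sc3ccc(N)cc3)ncnc2n1` keeps the core of compound 1 and has not yet been measured. It carries a single change: cyclohexyl in place of phenyl on a saturated chain carbon bound to an amide-type nitrogen and a saturated chain carbon. For the measured compounds named here, one measured step bears on it only loosely. The step of a 1.4-fold lower number from compound 1 to compound 2 (0.13 log units; within the scatter) came from bromo in place of hydrogen on an aromatic carbon, and it stayed within the scatter. Going by the values given here, no measured step replaces the ring itself, so the evidence is thin. No step beyond the scatter is therefore expected in this assay. The expected step is a 1.2-fold lower number from compound 1 to compound 3 (0.09 log units; within the scatter). For compound 3 the estimated half-life is 2.2 h, with an expected range from 1 h to 4.8 h.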

Compound 3, half-life: 0.8 h
The estimate for compound 3 lay 2.8-fold (0.44 log units) above the measured number; the measured number lies below the stated range.
By their numbers in this assay, from the lowest: compound 3; then compounds 2 and 1 (each within the scatter of the next).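

In this assay the ring on this saturated chain carbon, bound to an amide-type nitrogen and a saturated chain carbon, now shows a real effect on the read-out: cyclohexyl in place of phenyl gives a 3.4-fold lower number from compound 1 to compound 3 (0.53 log units; beyond the scatter), whereas bromo on the phenyl ring had stayed within the scatter. Cyclohexyl in place of 4-bromophenyl likewise gives a 2.5-fold lower number from compound 2 to compound 3 (0.40 log units; beyond the scatter), so at this position both aromatic rings stand apart from the non-aromatic one, though phenyl and cyclohexyl have the same heavy-atom count. Nothing measured here explains this difference.

The compounds shown leave open whether a pyridyl ring would stay with the aromatic compounds. They also leave open whether a piperidinyl ring or a cyclohexyl ring bearing a hydroxyl would stay with compound 3.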